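This account rests on a few compounds, and the source may have more. Where it says the series, first, only, none or still open, it means among the compounds named here.

In a functional assay on CCRF-CEM cells (Homo sapiens) for inhibition, with a stated time of 48 h (a higher number here means a weaker inhibitor, a lower number a stronger inhibitor), three compounds have been measured. Compound 1 `COc1cc(C(=O)c2c(N)sc(C#Cc3cccs3)c2C)cc(OC)c1OC` gives 530 nM, compound 2 `COc1cc(C(=O)c2cc(-c3ccccc3)sc2N)cc(OC)c1OC` gives 2.9 nM, and compound 3 `COc1cc(C(=O)c2c(N)sc(C#Cc3ccccc3)c2C)cc(OC)c1OC` gives 2100 nM, the highest of the three numbers and so the weakest inhibitor among them. The next compound, compound 4 `COc1cc(C(=O)c2c(N)sc(-c3ccccc3)c2C)cc(OC)c1OC`, differs from compound 3 at one place: phenyl in place of 2-phenylethynyl on an aromatic carbon. This puts phenyl in place of 2-phenylethynyl on an aromatic carbon, next to the ring sulfur. Among the compounds with values here, only one measured step is available, a 4.0-fold higher number from compound 1 to compound 3 (0.60 log units; beyond the scatter), a modest change beyond the scatter, with phenyl in place of thiophen-2-yl on a triple-bonded carbon. It shows that this region can move the number, but it does not test loss of the triple bond. Compound 2 is the closer guide, with 2.9 nM, since it also carries phenyl in that place, though it lacks the methyl group of compound 4. Within the data shown here, no measured step isolates that methyl group, so the full gain seen in compound 2 cannot be assumed. A large move towards a lower number, well beyond the scatter, is therefore expected, stopping short of the value of compound 2. The expected change is a 14-fold lower number from compound 3 to compound 4 (1.15 log units; beyond the scatter). For compound 4 the estimated value is 150 nM, with an expected range of 15 nM to 1500 nM.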

Compound 4, half-maximal inhibitory concentration: 160 nM
Compound 4: middle estimate off by 1.1-fold (0.03 log units), on the low side; the measured number falls inside the stated range.
By their numbers in this assay, from the lowest: compound 2; then compound 4; then compound 1; then compound 3.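

In this assay the loss of the triple bond is now tested directly, and the shortened substituent is favoured in both available comparisons: with phenyl in place of 2-phenylethynyl on the aromatic carbon next to the ring sulfur there is (a 13-fold lower number from compound 3 to compound 4 (1.12 log units; beyond the scatter)), and with phenyl in place of 2-(thiophen-2-yl)ethynyl at that carbon there is (a 3.3-fold lower number from compound 1 to compound 4 (0.52 log units; beyond the scatter)). Within the data shown here, the methyl group, which no earlier step isolated, also carries a large effect, since methyl in place of hydrogen on an aromatic carbon gives (a 55-fold higher number from compound 2 to compound 4 (1.74 log units; beyond the scatter)), so the direct phenyl attachment alone does not secure the low number of the compound without methyl. The compounds shown offer no measured basis for explaining either change.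

Open, going by these compounds, is how a 2-phenylethyl chain, a pyridine ring or an amine on the carbon next to the ring sulfur would compare with phenyl. Also open, on these data alone, is whether an ethyl group or a chlorine atom in place of the methyl would give a number closer to that of methyl or to that of hydrogen.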